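From compound 3 to compound 4: a new aryl group

The compounds below may be only part of what the source reports. "The series", "measured", "known", "first", "only" and "open" are said of these compounds alone.

In a functional assay on K562 cells (Homo sapiens) for antiproliferative activity, with a stated time of 72 h (a higher number here means a weaker inhibitor, a lower number a stronger inhibitor), three compounds sharing one core have been measured. Compound 1 `OC[C@H]1O[C@@H](n2cnc3c(NCc4ccccc4F)ncnc32)[C@H](O)[C@@H]1O` gives 33200 nM, compound 2 `OC[C@H]1O[C@@H](n2cnc3c(NCc4ccc(Cl)c(Cl)c4)ncnc32)[C@H](O)[C@@H]1O` gives 10800 nM, and compound 3 `OC[C@H]1O[C@@H](n2cnc3c(NCc4ccc(F)cc4F)ncnc32)[C@H](O)[C@@H]1O` gives 9600 nM. Compound 3 thus belongs to the pair with the lower numbers and cannot be separated from compound 2. The gap within that pair is small, a 1.1-fold lower number from compound 2 to compound 3 (0.05 log units; within the scatter). The remaining compound stands apart, with a 3.5-fold lower number from compound 1 to compound 3 (0.54 log units; beyond the scatter) and a 3.1-fold lower number from compound 1 to compound 2 (0.49 log units; beyond the scatter).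

Compound 4 `Cc1cccc(CNc2ncnc3c2ncn3[C@@H]2O[C@H](CO)[C@@H](O)[C@H]2O)c1O` has yet to be measured. Its change is 2-hydroxy-3-methylphenyl in place of 2,4-difluorophenyl on a saturated chain carbon bound to a nitrogen on an aromatic ring, which puts 2-hydroxy-3-methylphenyl in place of 2,4-difluorophenyl on a saturated chain carbon bound to a nitrogen on an aromatic ring. Going by the values given here, no measured compound carries the entering group, so the three steps offer only a rough guide to size, and each is modest at most. The estimate therefore stays inside the measured span, and the expected change is a 1.5-fold higher number from compound 3 to compound 4 (0.16 log units; within the scatter). Compound 4 is expected at 14000 nM, with an estimated range of 5000 nM to 40000 nM.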

Compound 4, half-maximal inhibitory concentration: 18000 nM
For compound 4 the middle estimate is 1.3-fold (0.11 log units) below the measured one; the range from low to high includes it.
By their numbers in this assay, from the lowest: compounds 3, 2, 4 and 1 (each within the scatter of the next, the first and the last beyond it).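

In this assay, the place on a saturated chain carbon bound to a nitrogen on an aromatic ring takes 2-hydroxy-3-methylphenyl with no step beyond the scatter against any halogenated group shown (a 1.9-fold higher number from compound 3 to compound 4 (0.27 log units; within the scatter); a 1.7-fold higher number from compound 2 to compound 4 (0.22 log units; within the scatter); a 1.8-fold lower number from compound 1 to compound 4 (0.27 log units; within the scatter)). Compound 4 alone carries a hydrogen-bond donor and acceptor in this aryl group, and it cannot be separated from compound 1 or compound 3, although those two lie beyond the scatter of each other. No measurement at hand accounts for this result.

The compounds shown do not separate the hydroxy from the methyl, so what each contributes alone stays open. Also open, as far as these compounds go, is how a methoxy group or an amine in place of that hydroxy would read in this assay.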